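This account rests on a few compounds, and the source may have more. Where it says the series, first, only, none or still open, it means among the compounds named here.

Of the compounds shown here, three on a shared core have been tested in a functional assay on NCI-H460 cells (Homo sapiens) for cytotoxicity, read by MTT assay; a lower number here means a stronger inhibitor, a higher number a weaker inhibitor. Compound 1 `Cc1ccccc1Nc1nc(C)c(C(=O)/C=C/c2ccccc2Cl)s1` gives only a limit there, > 25000 nM. Compound 2 `COc1cccc(/C=C/C(=O)c2sc(Nc3cccc(Cl)c3)nc2C)c1` likewise gives only a limit, > 25000 nM. Compound 3 `COc1cc(/C=C/C(=O)c2sc(Nc3ccc(Cl)c(Cl)c3)nc2C)cc(OC)c1OC` also reaches only a limit, > 25000 nM. Compound 3 thus stands with the other two at the limit of > 25000 nM in this assay, at which 3 of the 3 values shown sit; no number separates any of the three. Compound 4 `COc1cc(/C=C/C(=O)c2sc(Nc3cccc(Cl)c3)nc2C)cc(OC)c1OC` has not yet been measured in this assay. The change from compound 3 to compound 4 is hydrogen in place of chloro on an aromatic carbon. Since compounds 1, 2 and 3 all sit at the limit, no step beyond the scatter is expected, and the step that the limit leaves unreadable from compound 3 to compound 4 is estimated to be none in either direction. Compound 4 is expected to give 35000 nM, within 12000 nM to 100000 nM, most likely again only as a limit.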

Compound 4, half-maximal inhibitory concentration: > 25000 nM
Compound 4: a limit, no number (the forecaster's own chance of this, stated with the estimate: 80%); the middle value does not contradict the limit.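

No step from compound 3 to compound 4 can be read, as both give only a limit in this assay: the limit of > 25000 nM in this assay, at which 4 of the 4 values shown sit.

The compounds shown leave open whether any change on the shared core gives a measurable potency in this assay.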